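The source may report more compounds than this note shows. Statements on the series, on what has been measured and on what is new or still open speak of the compounds shown alone.

Measured in a functional assay on KB cells (Homo sapiens) for cytotoxicity (on this read-out lower numbers stand for stronger inhibition and higher numbers for weaker inhibition), each entry a limit of the assay:

- compound 1 `COCCOCn1cc(C#N)c2c(N)ncnc21`: > 100000 nM
- compound 2 `N#Cc1cn(Cc2ccccc2)c2ncnc(N)c12`: > 100000 nM
- compound 3 `Cc1ccccc1Cn1cc(C#N)c2c(N)ncnc21`: > 100000 nM

Compound 2 stands at > 100000 nM, which is a limit and not a number. The two other values shown for the series are also limits, so compound 2 has no numerical reference point in this assay.

Compound 4 `CC(C)(C)c1ccc(Cn2cc(C#N)c3c(N)ncnc32)cc1` follows from compound 2 with tert-butyl in place of hydrogen on an aromatic carbon of a six-membered aromatic ring of carbon only, para to a large group: tert-butyl in place of hydrogen on an aromatic carbon.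

The closest measured change is methyl in place of hydrogen on an aromatic carbon, which gives a step that the two limits leave unreadable from compound 2 to compound 3. The change of phenyl in place of 2-methoxyethoxy gives a step that the two limits leave unreadable from compound 1 to compound 2. Neither step has a readable size, and the whole series shares one outcome: the limit of > 100000 nM in this assay, at which 3 of the 3 values shown sit.

On the step to compound 3, a step that the two limits leave unreadable from compound 2 to compound 3, no change beyond the scatter is expected for the larger group, and compound 4 will most likely also be reported as a limit. As far as these compounds go, the estimated step is a number no higher from compound 2 to compound 4 (the limit leaves the size open), and its direction stays open. For compound 4 the expected value is 100000 nM, with an estimated range of 30000 nM to 200000 nM.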

Compound 4, half-maximal inhibitory concentration: 3000 nM
Compound 4: the middle estimate sits 33-fold (1.52 log units) above what was measured, and the stated range ends above it.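

In this assay, tert-butyl in place of hydrogen on an aromatic carbon, para to a large group, gives an at least 33-fold lower number from compound 2 to compound 4 (1.52 log units; beyond the scatter), the only readable step in the series; the other steps shown cannot be read. For compound 2, > 100000 nM is a limit of the assay and not a number. Compound 4 is therefore the only compound shown with a measured number, and this change on the six-membered aromatic ring is the only one shown that moves the read-out off the shared limit: the limit of > 100000 nM in this assay, at which 3 of the 4 values shown sit.

The compounds shown do not separate the contribution of the tert-butyl group from that of its place on the ring, as they offer no second group at this carbon and no tert-butyl group elsewhere on the ring. As far as these compounds go, whether an isopropyl group, a methoxy group or an amine at this same aromatic carbon would come close to the value of compound 4, 3000 nM, stays open. From the compounds shown here alone, whether any of these groups would return to the shared limit stays open as well.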